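This account rests on a few compounds, and the source may have more. Where it says the series, first, only, none or still open, it means among the compounds named here.

The measured compounds:
compound 1, `COc1cc(-c2nnc3n2NC(c2ccco2)C(C(=O)c2ccc(Br)cc2)S3)cc(OC)c1OC`, gives > 100000 nM in a functional assay on MCF7 cells (Homo sapiens) for cytotoxicity, read by MTT assay, with a stated time of 48 h (a higher number here means a weaker inhibitor, a lower number a stronger inhibitor), which is a limit of the assay.
compound 2, `COc1cc(-c2nnc3n2NC(c2ccco2)C(C(=O)c2ccc(Cl)cc2)S3)cc(OC)c1OC`, gives > 100000 nM in this assay, again a limit of the assay.
compound 3, `COc1cc(-c2nnc3n2NC(c2ccco2)C(C(=O)c2ccc(F)c(F)c2)S3)cc(OC)c1OC`, gives 73200 nM in this assay.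

Compound 3 thus holds the only number shown; the other two values sit at a limit, (the limit of > 100000 nM in this assay, at which 2 of the 3 values shown sit). The step from compound 1 to compound 3 reads an at least 1.3-fold lower number from compound 1 to compound 3 (0.13 log units; that floor lies within the scatter), and from compound 2 to compound 3 an at least 1.3-fold lower number from compound 2 to compound 3 (0.13 log units; that floor lies within the scatter); the step from compound 1 to compound 2 is a step that the two limits leave unreadable from compound 1 to compound 2.

Compound 4, `COc1cc(-c2nnc3n2NC(c2ccco2)C(C(=O)c2ccc(C(F)(F)F)cc2)S3)cc(OC)c1OC`, differs from compound 3 by 4-(trifluoromethyl)phenyl in place of 3,4-difluorophenyl on a carbonyl carbon. For the measured compounds named here, no measured step covers this exchange; the two that bear on the same carbonyl carbon swapped one halogenated phenyl for another and moved the number only by floors within the scatter. He therefore expects no step beyond the scatter in this assay, with a fair chance that compound 4 again reaches only the limit. He estimates compound 4 at 80000 nM, between 30000 nM and 200000 nM, meaning an expected step of a 1.1-fold higher number from compound 3 to compound 4 (0.04 log units; within the scatter).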

Compound 4, half-maximal inhibitory concentration: 33600 nM
The estimate for compound 4 lay 2.4-fold (0.38 log units) above the measured number; the measured number falls inside the stated range.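

On the carbonyl carbon, an exchange of one aryl group for another now moves the number beyond the scatter in this assay: 4-(trifluoromethyl)phenyl in place of 3,4-difluorophenyl gives a 2.2-fold lower number from compound 3 to compound 4 (0.34 log units; beyond the scatter). Trifluoromethyl in place of chloro on an aromatic carbon gives an at least 2.9-fold lower number from compound 2 to compound 4 (0.47 log units; beyond the scatter), and trifluoromethyl in place of bromo gives an at least 2.9-fold lower number from compound 1 to compound 4 (0.47 log units; beyond the scatter), which makes compound 4 the strongest of the four compounds shown. Compound 1 and compound 2 stay at a limit, so these last two steps are floors and not sizes: the limit of > 100000 nM in this assay, at which 2 of the 4 values shown sit.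

The compounds shown leave open whether trifluoromethyl is special here, or whether a nitrile, a methoxy group or a carboxylic acid on that aromatic carbon would give a similar number. They also leave open whether the step would hold with changes elsewhere on the shared core.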